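Naphthyl in place of tert-butylphenyl: what to expect

The compounds below may be only part of what the source reports. "The series", "measured", "known", "first", "only" and "open" are said of these compounds alone.

Measured compounds:
Compound 1 `Cc1ccc(CC2(c3ccccc3)NC(=O)N(Cc3ccc(C(=O)NO)cc3)C2=O)cc1`: 82.4 nM
Compound 2 `CC(C)(C)c1ccc(CC2(c3ccccc3)NC(=O)N(Cc3ccc(C(=O)NO)cc3)C2=O)cc1`: 115 nM

Both numbers come from an assay on isolated protein for inhibition of protein deacetylase HDAC6 (Homo sapiens), read by fluorescence, with stated times of 10 min and 2 h; a lower number here means a stronger inhibitor, a higher number a weaker inhibitor. On the numbers shown compound 2 and compound 1 are not separated beyond the scatter, as a 1.4-fold higher number from compound 1 to compound 2 (0.14 log units; within the scatter) shows, so neither can be called the stronger inhibitor.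

Compound 3 `O=C(NO)c1ccc(CN2C(=O)NC(Cc3cccc4ccccc34)(c3ccccc3)C2=O)cc1` is not yet measured. It differs from compound 2 in one place: naphthalen-1-yl in place of 4-(tert-butyl)phenyl on a saturated chain carbon bound to a saturated ring carbon. Among the measured compounds shown here, the only measured step, a 1.4-fold higher number from compound 1 to compound 2 (0.14 log units; within the scatter), swapped one small group on that aromatic ring for a larger one and did not move the number beyond the scatter; it bears only loosely on the present change, which exchanges the whole ring for a two-ring system of the same atom count. For the measured compounds named here, with no step of this kind measured, no change beyond the scatter is expected, so compound 3 is estimated at 100 nM, between 40 nM and 250 nM, which amounts to an expected 1.2-fold lower number from compound 2 to compound 3 (0.06 log units; within the scatter).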

Compound 3, half-maximal inhibitory concentration: 91.9 nM
Beside the measured number, compound 3's estimate is 1.1-fold (0.04 log units) above it; low and high end bracket the measured number.
By their numbers in this assay, from the lowest: compounds 1, 3 and 2 (each within the scatter of the next).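

In this assay, exchanging the single aromatic ring for two gives a 1.3-fold lower number from compound 2 to compound 3 (0.10 log units; within the scatter) and, set against the methyl-bearing ring, gives a 1.1-fold higher number from compound 1 to compound 3 (0.05 log units; within the scatter) as well. On a saturated chain carbon bound to a saturated ring carbon, 4-methylphenyl, 4-(tert-butyl)phenyl and naphthalen-1-yl therefore cannot be told apart by their numbers, and this now holds for replacing the whole ring, not only for changing a small group on it. No measurement is available here that would explain why these three groups read alike.

Going by these compounds, all three groups are built of carbon only, so it remains open whether a ring carrying an amine or a carboxylic acid would give a similar number. A longer chain leading to the aromatic ring also remains untested among the compounds shown.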